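Anilide substituent changes on a shared azo-indole core

A few compounds are considered here, and "the series" means these few. Any claim that something is new, unique, unknown or untested is made for them only; others in the source may bear on it.

The three measured compounds share one core and differ only in the group on the amide-type nitrogen. Compound 1 `O=C(Nc1ccccc1)c1ccc(/N=N\c2c[nH]c3ccccc23)cc1` carries plain phenyl, and in a functional assay on MCF7 cells (Homo sapiens) for inhibition, read by MTT assay, with a stated time of 72 h (a higher number here means a weaker inhibitor, a lower number a stronger inhibitor), compound 1 gives 147000 nM. Compound 2 `Cc1ccc(C)c(NC(=O)c2ccc(/N=N\c3c[nH]c4ccccc34)cc2)c1` carries 2,5-dimethylphenyl, and compound 2 gives 29900 nM. Compound 3 `O=C(Nc1cccc(Cl)c1)c1ccc(/N=N\c2c[nH]c3ccccc23)cc1` carries 3-chlorophenyl, and compound 3 gives 82700 nM. Compound 3 stands second highest of the three numbers, with compound 1 nearest and compound 2 furthest: a 1.8-fold lower number from compound 1 to compound 3 (0.25 log units; within the scatter), whereas a 2.8-fold higher number from compound 2 to compound 3 (0.44 log units; beyond the scatter).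

Compound 4 `Cc1ccccc1NC(=O)c1ccc(/N=N\c2c[nH]c3ccccc23)cc1` is reached from compound 3 by 2-methylphenyl in place of 3-chlorophenyl on an amide-type nitrogen. Among the measured compounds shown here, two measured steps bear on this. a 4.9-fold lower number from compound 1 to compound 2 (0.69 log units; beyond the scatter), so two methyl groups on the phenyl pull the number down beyond the scatter. a 2.8-fold higher number from compound 2 to compound 3 (0.44 log units; beyond the scatter), so the chloro analogue sits higher than the dimethyl one. A single methyl is expected to place compound 4 between compound 1 and compound 2, and the step is therefore expected to be a modest lowering, a 1.7-fold lower number from compound 3 to compound 4 (0.22 log units; within the scatter), probably near the edge of the scatter. Compound 4 is estimated at 50000 nM, with a range of 20000 nM to 130000 nM.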

Compound 4, half-maximal inhibitory concentration: 73400 nM
Compound 4: the middle estimate sits 1.5-fold (0.17 log units) below what was measured; low and high end bracket the measured number.
By their numbers in this assay, from the lowest: compound 2; then compounds 4, 3 and 1 (each within the scatter of the next).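

On the amide-type nitrogen, 2-methylphenyl and 3-chlorophenyl are not separated in this assay (a 1.1-fold lower number from compound 3 to compound 4 (0.05 log units; within the scatter)), so exchanging one substituted phenyl for the other, with the same count of heavy atoms, leaves the number within the scatter. Among the compounds shown here, a single methyl does not reproduce the shift seen with 2,5-dimethylphenyl: plain phenyl and 2-methylphenyl remain within the scatter (a 2.0-fold lower number from compound 1 to compound 4 (0.30 log units; within the scatter)), whereas removing one methyl from 2,5-dimethylphenyl gives a step beyond it (a 2.5-fold higher number from compound 2 to compound 4 (0.39 log units; beyond the scatter)), and compound 2 is now the only compound with steps to all three others printed as beyond the scatter. No measurement in hand accounts for this difference between one methyl and two.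

The compounds shown leave open whether the two substituents can be compared at a single ring position, as 3-methylphenyl and 3-chlorophenyl or 2-methylphenyl and 2-chlorophenyl would allow. Also open, on these data alone, is whether the lower number of compound 2 persists with other groups on the phenyl, such as methoxy, trifluoromethyl, an amine or a carboxylic acid.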